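The compounds below may be only part of what the source reports. "The series", "measured", "known", "first", "only" and "open" are said of these compounds alone.

Working notes on the series. Compound 1 `Cc1cc(C)c(-c2c[nH]nc2C)cc1NC(=O)c1ccc(OCc2ccccn2)cc1` and compound 2 `Cc1cc(C)c(-c2cccnc2)cc1NC(=O)c1ccc(OCc2ccccn2)cc1` share one core and differ only in the aromatic group carried on it; the read-out followed is a physicochemical assay for lipophilicity; on this read-out higher numbers stand for higher lipophilicity and lower numbers for lower lipophilicity. In this assay compound 1 gives > 3, a limit of the assay and not a number. In this assay compound 2 gives > 3, likewise a limit and not a number. For the measured compounds named here, the one measured step, a step that the two limits leave unreadable from compound 1 to compound 2, cannot be read because the limit of > 3 in this assay, at which 2 of the 2 values shown sit, leaves no number on either side. Compound 2 therefore stands at the edge of what the assay reports, with no value of its own beyond that limit.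

Compound 3 `Cc1cc(C)c(-c2ccc(N)cn2)cc1NC(=O)c1ccc(OCc2ccccn2)cc1` differs from compound 2 in one place: 5-aminopyridin-2-yl in place of pyridin-3-yl on an aromatic carbon. Going by the values given here, no measured step bears on this change, since the only step in the set, from compound 1 to compound 2, is itself unreadable in size and direction. With an amino group entering on the pyridine, the step expected from compound 2 to compound 3 is a number no higher from compound 2 to compound 3 (the limit leaves the size open). For compound 3 the estimated value in this assay is 3, expected to fall between 2.3 and 3.7. A further limit rather than a number remains a real possibility for compound 3.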

Compound 3, distribution coefficient: 3.2
Beside the measured number, compound 3's estimate is 0.20 log units below it; the range from low to high includes it.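

Neither step into compound 3, from compound 1 or from compound 2, can be read in this assay, because compound 1 and compound 2 each carry a limit and not a number: the limit of > 3 in this assay, at which 2 of the 3 values shown sit.

The compounds shown leave open whether 5-aminopyridin-2-yl in place of pyridin-3-yl moves the read-out up or down, and by how much.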